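The compounds below may be only part of what the source reports. "The series", "measured", "known", "first", "only" and "open" are said of these compounds alone.

Notes on the series. Compound 1 `COC(=O)c1c(-c2ccc(OC)cc2)oc2ccccc2c1=O` carries a methoxy group, compound 2 `COC(=O)c1c(-c2ccc(Br)cc2)oc2ccccc2c1=O` a bromo group and compound 3 `COC(=O)c1c(-c2ccc([N+](=O)[O-])cc2)oc2ccccc2c1=O` a nitro group on the same aromatic carbon of the shared core. In a functional assay on MCF7 cells (Homo sapiens) for cytotoxicity, read by MTT assay, with a stated time of 6 days (a lower number here means that less compound is needed, a higher number that more compound is needed for the effect), compound 1 gives only a limit, > 25 ug/mL. In this assay compound 2 likewise gives a limit, > 25 ug/mL. In this assay compound 3 also gives a limit, > 25 ug/mL. Compound 3 therefore stands with the other two at the limit described by the limit of > 25 ug/mL in this assay, at which 3 of the 3 values shown sit. The steps a step that the two limits leave unreadable from compound 1 to compound 2, a step that the two limits leave unreadable from compound 1 to compound 3 and a step that the two limits leave unreadable from compound 2 to compound 3 are all left unreadable by these limits. Compound 4 `COC(=O)c1c(-c2ccc(N)cc2)oc2ccccc2c1=O` differs from compound 3 by amino in place of nitro on an aromatic carbon. Among the compounds with values here, no measured step involves an amino group, so no step size can be read from the series. The step that the limit leaves unreadable from compound 3 to compound 4 is expected to stay within scatter, most likely ending again at a limit. The expected value for compound 4 in this assay is 30 ug/mL, within 8 ug/mL to 100 ug/mL.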

Compound 4, concentration for half-maximal effect: > 25 ug/mL
Compound 4 was reported as a limit (the forecaster's own chance of this, stated with the estimate: 70%); the middle value lies beyond the limit too.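

Compound 4 adds no readable step against compound 1, compound 2 or compound 3, and all four compounds stand at the same limit: the limit of > 25 ug/mL in this assay, at which 4 of the 4 values shown sit.

The compounds shown leave open whether any group on this aromatic carbon gives a readable value in this assay.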